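Methyl step from compound 2 to compound 3

This account rests on a few compounds, and the source may have more. Where it says the series, first, only, none or still open, it means among the compounds named here.

In a functional assay on A549 cells (Homo sapiens) for cytotoxicity, with a stated time of 48 h (on this read-out lower numbers stand for stronger inhibition and higher numbers for weaker inhibition), compound 1 (`CCOc1ccc2oc(/C=C/[S+](C)[O-])cc(=O)c2c1`) gives 1500 nM and compound 2 (`C[S+]([O-])/C=C/c1cc(=O)c2ccccc2o1`) gives 1900 nM, so the two stand level within the scatter. Compound 3 (`Cc1c(/C=C/[S+](C)[O-])oc2ccccc2c1=O`) differs from compound 2 by one change: methyl in place of hydrogen on an aromatic carbon. Among the compounds with values here, the only measured step, a 1.3-fold higher number from compound 1 to compound 2 (0.10 log units; within the scatter), is hydrogen in place of ethoxy at a different place, so it bears only indirectly on this change. No step beyond the scatter is therefore expected in this assay. The estimated step is a 1.1-fold higher number from compound 2 to compound 3 (0.02 log units; within the scatter). The estimate for compound 3 is 2000 nM, with an expected range of 800 nM to 5000 nM.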

Compound 3, half-maximal inhibitory concentration: 1500 nM
The estimate for compound 3 lay 1.3-fold (0.12 log units) above the measured number; the range from low to high includes it.
By their numbers in this assay, from the lowest: compounds 1, 3 and 2 (each within the scatter of the next).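

In this assay, methyl in place of hydrogen on this aromatic carbon, ortho to a group of 5 heavy atoms and two atoms from the ring oxygen, gives a 1.3-fold lower number from compound 2 to compound 3 (0.10 log units; within the scatter). Within the data shown here, the position therefore accepts methyl with no step beyond the scatter, and this is the only reading at this carbon, since the ethoxy step lies at a different place. No measurement on hand bears on this result. Still open, on these data alone, is whether a longer chain, an amine or a carboxylic acid at this carbon would give a step beyond the scatter.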